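A few compounds are considered here, and "the series" means these few. Any claim that something is new, unique, unknown or untested is made for them only; others in the source may bear on it.

Three compounds share one core and differ only in the small group attached to it. Compound 1 `CCNc1ncc(C#Cc2ccccc2)cn1` carries an ethylamino group on that core, compound 2 `CSc1ncc(C#Cc2ccccc2)cn1` a methylthio group and compound 3 `Cc1ncc(C#Cc2ccccc2)cn1` a methyl group. All three were tested in an assay on HEK293 cells for positive allosteric modulation of metabotropic glutamate receptor 5 (Rattus norvegicus); a higher number here means that more compound is needed for the effect, a lower number that less compound is needed. Compound 1 gives no number at all and is recorded as "not active" (no number reported). Compound 3 likewise comes out as "not active" (no number reported). Only compound 2 yields a value, and a very weak one: compound 2 gives 120000 nM. So compound 1 stands among the two inactive members of this small set, with nothing to place it above or below compound 3.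

Compound 4 `CCNc1ncc(C#Cc2cccc(C)c2)cn1` keeps everything in compound 1 and changes the phenyl ring on the far side of the molecule: methyl in place of hydrogen on an aromatic carbon. Whether such a change matters in this assay has not been seen in any measured pair here, so no step size can be read off. With compound 1 showing no activity, any appearance of a number for compound 4 would itself be a move beyond the scatter, but the data give no ground to expect more than weak potency. Compound 4 is therefore estimated to give 30000 nM in this assay, with a range from 5000 nM to 200000 nM.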

Compound 4, half-maximal effective concentration: "not active" (no number reported)
No number was reported for compound 4, so the estimate cannot be set against anything.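

In this assay compound 1 gives "not active" (no number reported) and compound 4 gives "not active" (no number reported), so no step can be read between them. The compounds shown leave open whether the added methyl group changes potency at all on this shared core. No supporting information bears on this result.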